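A few compounds are considered here, and "the series" means these few. Any claim that something is new, unique, unknown or untested is made for them only; others in the source may bear on it.

Measured so far in a functional assay on cells (Cancer cell lines, Homo sapiens) for cytotoxicity, with a stated time of 48 h; a higher number here means a weaker inhibitor of growth, a lower number a stronger inhibitor of growth:
Compound 1 `COc1cc2c(/C=C3/C(=O)Nc4ccc(Cl)cc43)c(Cl)n(Cc3cc(OC)c(OC)c(OC)c3)c2cc1C` — compound 1 gives 2950 nM.
Compound 2 `COc1cc2c(/C=C3/C(=O)Nc4cccc(Cl)c43)c(Cl)n(Cc3cc(OC)c(OC)c(OC)c3)c2cc1C` — compound 2 gives 3240 nM.

For the measured compounds named here, compound 1 carries the lower of the two numbers, but the only measured step, a 1.1-fold higher number from compound 1 to compound 2 (0.04 log units; within the scatter), does not separate it from compound 2; the two sit within the scatter of each other and no order between them can be read.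

Compound 3 `COc1ccc2c(c1)/C(=C\c1c(Cl)n(Cc3cc(OC)c(OC)c(OC)c3)c3cc(C)c(OC)cc13)C(=O)N2` differs from compound 1 by methoxy in place of chloro on an aromatic carbon. Going by the values given here, no measured pair shows a chloro replaced by a methoxy, so there is no direct precedent for this change. Among the compounds with values here, the single measured step concerns the same ring of the shared core: shifting the chloro to another carbon of that ring, a 1.1-fold higher number from compound 1 to compound 2 (0.04 log units; within the scatter), left the number where it was. Within the data shown here, that is the only guide available, and it argues that this ring tolerates a change of substituent without a large move in the read-out.

The expectation for compound 3 in this assay is therefore a step no larger than the scatter, a 1.0-fold higher number from compound 1 to compound 3 (0.01 log units; within the scatter). Compound 3 is expected to give about 3000 nM, with a range from 1200 nM to 7500 nM.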

Compound 3, concentration for 50% growth inhibition: 29500 nM
Compound 3: middle estimate off by 9.8-fold (0.99 log units), on the low side; measured number above the stated range.
By their numbers in this assay, from the lowest: compounds 1 and 2 (each within the scatter of the next); then compound 3.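

In this assay, the carbon that holds the chloro in compound 1 proves sensitive to the identity of its substituent: methoxy in place of chloro there gives a clear loss of growth inhibition (a 10-fold higher number from compound 1 to compound 3 (1.00 log units; beyond the scatter)). The earlier step (a 1.1-fold higher number from compound 1 to compound 2 (0.04 log units; within the scatter)) only moved the chloro to another carbon of the same ring, so it showed that this one relocation left the read-out within the scatter and said nothing about exchanging chloro for a different group. The series now holds one step within the scatter and one beyond it on this ring, and nothing shown accounts for the difference between them.

On these data alone, it remains open whether the loss is tied to the departure of chloro or to the arrival of methoxy, and a methyl, a fluoro or an amine on the same carbon would help separate these two readings. Also open, as far as these compounds go, is whether methoxy in place of the chloro of compound 2 would produce a step of similar size, or whether the effect belongs to the carbon that is meta to a fused ring and para to a fused ring.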